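Isobutyl to methyl: from compound 2 to compound 3

The source may hold more compounds than are shown below. What is called first, only, known or untested is meant among the compounds shown, and "the series" means these compounds.

Measured in an ADME assay on HEL cells (Homo sapiens) for inhibition; a higher number here means that more compound is tolerated, a lower number that less compound is tolerated:
- compound 1 `CCCCCc1ccc(-c2cc3cn([C@H]4C[C@H](OC(=O)[C@@H](NC(=O)[C@@H]5CCCN5C(=O)[C@@H](N)C(C)C)C(C)C)[C@@H](CO)O4)c(=O)nc3o2)cc1` gives 17000 nM
- compound 2 `CCCCCc1ccc(-c2cc3cn([C@H]4C[C@H](O)[C@@H](COC(=O)[C@H](CC(C)C)NC(=O)[C@@H]5CCCN5C(=O)[C@@H](N)C(C)C)O4)c(=O)nc3o2)cc1` gives 31000 nM

Compound 2 stands within the usual scatter of compound 1, so these two numbers cannot be separated and neither can be ranked over the other. The next compound to read is compound 3 `CCCCCc1ccc(-c2cc3cn([C@H]4C[C@H](O)[C@@H](COC(=O)[C@H](C)NC(=O)[C@@H]5CCCN5C(=O)[C@@H](N)C(C)C)O4)c(=O)nc3o2)cc1`, which differs from compound 2 at one place: hydrogen in place of isopropyl on a saturated chain carbon, two bonds along the chain from an amide-type nitrogen and a carbonyl carbon. In words, hydrogen takes the place of isopropyl on a saturated chain carbon, two bonds along the chain from an amide-type nitrogen and a carbonyl carbon, and cut one bond further out the same change reads isobutyl to methyl.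

Going by the values given here, no measured pair shows this change, so the data give no direct guide to its size. Among the compounds with values here, the only anchors are compound 1 at 17000 nM and compound 2 at 31000 nM in the same range. No step beyond the scatter is therefore expected in this assay, in either direction. The estimated step of a 1.0-fold lower number from compound 2 to compound 3 (0.01 log units; within the scatter) is expected to stay small. For compound 3 the expected value is 30000 nM with an estimated range from 13000 nM to 70000 nM as the working figures.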

Compound 3, half-maximal cytotoxic concentration in the HEL assay: 44000 nM
Estimate against measurement, compound 3: 1.5-fold (0.17 log units) below, within the range that was stated.
By their numbers in the HEL assay, from the lowest: compounds 1, 2 and 3 (each within the scatter of the next, the first and the last beyond it).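

Going by these compounds alone, in the HEL assay the first direct reading of isobutyl to methyl at this saturated chain carbon is a 1.4-fold higher number from compound 2 to compound 3 (0.15 log units; within the scatter), so the change gives no separable effect on the tolerated concentration and compound 2 and compound 3 cannot be ranked there. In a physicochemical assay for solubility, with a stated time of 4 h (a higher number here means a more soluble compound, a lower number a less soluble compound), the same change does register, with compound 2 at 14000 ug/mL and compound 3 at 6100 ug/mL. The compound carrying methyl in place of isobutyl has the lower solubility: the measured solubility of compound 2, 14000 ug/mL, and of compound 3, 6100 ug/mL, a 2.3-fold lower number (0.36 log units; beyond the scatter) For this one pair the two read-outs therefore part ways, with a step inside the scatter in the HEL assay and a modest step beyond it in the physicochemical assay, and compound 2 keeps the higher solubility number with nothing separable given up in the tolerated concentration.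

Only isobutyl and methyl stand at this carbon, so one pair cannot tell whether the solubility step tracks the size of the side chain or whether it holds at other places on the compound. As far as these compounds go, how an ethyl group, a longer chain, or a side chain carrying an amine or a carboxylic acid would read in the HEL assay and the physicochemical assay remains open.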